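A New Phenyl Group on the Sulfonamide Nitrogen

The source may report more compounds than this note shows. Statements on the series, on what has been measured and on what is new or still open speak of the compounds shown alone.

Compound 3 (`O=S(=O)(Nc1cc(F)cc(Cl)c1)c1ccc(-c2cnc(C3CC3)o2)cc1`) gives 77500 nM in a functional assay on cells (leukaemia cell line, Homo sapiens) for inhibition, read by sulforhodamine B assay, with a stated time of 48 h (a higher number here means a weaker inhibitor of growth, a lower number a stronger inhibitor of growth), and cannot be separated from the two related compounds measured with it. Compound 1 (`O=S(=O)(Nc1cccc(Cl)c1)c1ccc(-c2cnc(C3CC3)o2)cc1`) gives 54200 nM and compound 2 (`O=S(=O)(Nc1ccc(Br)c(Cl)c1)c1ccc(-c2cnc(C3CC3)o2)cc1`) gives 70300 nM in this assay on the same scale. All the steps among these three are small. Adding a bromo gives a 1.3-fold higher number from compound 1 to compound 2 (0.11 log units; within the scatter) and adding a fluoro gives a 1.4-fold higher number from compound 1 to compound 3 (0.16 log units; within the scatter) as the result. Among the measured compounds shown here, exchanging one substituted phenyl group for the other gives a 1.1-fold higher number from compound 2 to compound 3 (0.04 log units; within the scatter) and is the closest precedent for what follows.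

The next structure, compound 4 (`Cc1ccc(Cl)c(NS(=O)(=O)c2ccc(-c3cnc(C4CC4)o3)cc2)c1`), differs from compound 3 by 2-chloro-5-methylphenyl in place of 3-chloro-5-fluorophenyl on a sulfonamide nitrogen and so has 2-chloro-5-methylphenyl in place of 3-chloro-5-fluorophenyl on a sulfonamide nitrogen. For the measured compounds named here, no measured compound carries this group or any methyl group, so the evidence is indirect and the range must stay wide. Still, the whole-group exchange between compound 2 and compound 3 left the numbers within the scatter, and no step beyond the scatter is expected here. The estimated change is a 1.3-fold lower number from compound 3 to compound 4 (0.10 log units; within the scatter) in this assay and would not be distinguishable from repeat variation. For compound 4 the expected value is 62000 nM with an estimated range of 32000 nM to 115000 nM as the likely span.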

Compound 4, concentration for total growth inhibition: 52800 nM
The estimate for compound 4 lay 1.2-fold (0.07 log units) above the measured number; the measured number falls inside the stated range.
By their numbers in this assay, from the lowest: compounds 4, 1, 2 and 3 (each within the scatter of the next).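

In this assay, the steps of a 1.5-fold lower number from compound 3 to compound 4 (0.17 log units; within the scatter) and a 1.3-fold lower number from compound 2 to compound 4 (0.12 log units; within the scatter) and a 1.0-fold lower number from compound 1 to compound 4 (0.01 log units; within the scatter) show that 2-chloro-5-methylphenyl on a sulfonamide nitrogen cannot be separated from any of the three earlier groups. The earlier compounds shown here carried only halogens on this phenyl group, so compound 4 adds the first case with a methyl group, and even this exchange leaves all four compounds within the scatter of one another in this assay. Nothing measured here offers an account of why the numbers stay so close.

All the steps seen so far are within the scatter, so the compounds shown do not reveal any group on the sulfonamide nitrogen that separates itself in this assay, and they give no sign of how far this tolerance extends. As far as these compounds go, what an amine or a carboxylic acid on this phenyl group would do remains open, as does whether a longer chain in place of the phenyl group, or any change to the shared core, would move the number beyond the scatter.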